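Changing the Sulfonyl Aryl Group of Compound 3

This account rests on a few compounds, and the source may have more. Where it says the series, first, only, none or still open, it means among the compounds named here.

The measured compounds, with their results in a functional assay on MCF7 cells (Homo sapiens) for antiproliferative activity, read by MTT assay, with a stated time of 48 h; a higher number here means a weaker inhibitor, a lower number a stronger inhibitor:
Compound 1 `O=C(Nc1cccc(/C=C/C(=O)c2nc3ccccc3[nH]2)c1)c1ccc(Cl)cc1` gives 8410 nM.
Compound 2 `O=C(Nc1cccc(/C=C/C(=O)c2nc3ccccc3[nH]2)c1)c1cccc(Br)c1` gives 5210 nM.
Compound 3 `O=C(/C=C/c1cccc(NS(=O)(=O)c2ccccc2Cl)c1)c1nc2ccccc2[nH]1` gives 4280 nM.

Among these three, compound 3 carries the lowest number, but its separation from the others is small: a 2.0-fold lower number from compound 1 to compound 3 (0.29 log units; within the scatter) and a 1.2-fold lower number from compound 2 to compound 3 (0.09 log units; within the scatter), both within the scatter, and likewise a 1.6-fold lower number from compound 1 to compound 2 (0.21 log units; within the scatter). Compound 4 `Cc1ccc(S(=O)(=O)Nc2cccc(/C=C/C(=O)c3nc4ccccc4[nH]3)c2)cc1C` has not yet been measured. It differs from compound 3 in one place: 3,4-dimethylphenyl in place of 2-chlorophenyl on a sulfonyl sulfur. For the measured compounds named here, no measured step alters the aryl group on the sulfonyl sulfur. The closest comparison is the swap of one halogenated aryl group for another on the carbonyl carbon, where a 1.6-fold lower number from compound 1 to compound 2 (0.21 log units; within the scatter) stayed within the scatter, and the exchange of the amide for a sulfonamide also produced nothing beyond the scatter. On this basis no step beyond the scatter is expected in this assay for compound 4, whose estimated value is 4500 nM, within 1500 nM to 13000 nM, corresponding to an expected step of a 1.1-fold higher number from compound 3 to compound 4 (0.02 log units; within the scatter).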

Compound 4, half-maximal inhibitory concentration: 5860 nM
Estimate against measurement, compound 4: 1.3-fold (0.11 log units) below; low and high end bracket the measured number.
By their numbers in this assay, from the lowest: compounds 3, 2, 4 and 1 (each within the scatter of the next).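

For the compounds shown here, this is the only step in this assay that alters the aryl group on the sulfonyl sulfur itself, and with 3,4-dimethylphenyl in place of 2-chlorophenyl it gives a 1.4-fold higher number from compound 3 to compound 4 (0.14 log units; within the scatter). At this position, then, an aryl group carrying only carbon substituents stays within the scatter of one carrying chlorine, so the chlorine of compound 3 is not needed for a value in this range. Nothing at hand explains this result or ties it to a property of either group.

On these data alone, each of the four compounds lies within the scatter of the next, so it remains open whether any group on the sulfonyl sulfur can move the number beyond the scatter. As far as these compounds go, how an amine or a carboxylic acid on that aryl ring, or a longer alkyl chain in place of the ring, would behave also remains open.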